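A Pyridyloxy Swap on the Muscarinic M5 Modulator Core

This account rests on a few compounds, and the source may have more. Where it says the series, first, only, none or still open, it means among the compounds named here.

Three compounds sharing the core of compound 1 `O=C1C(=O)N(Cc2ccc(-c3cccnc3)cn2)c2ccc(OC(F)(F)F)cc21` were examined in a functional assay on CHO cells for positive allosteric modulation of muscarinic acetylcholine receptor M5 (Homo sapiens), read by FLIPR and calcium flux, with a stated time of 1 h; a lower number here means that less compound is needed, a higher number that more compound is needed for the effect. Compound 1 reaches only the limit of the assay, giving > 30000 nM (the limit of > 30000 nM in this assay, at which 1 of the 3 values shown sits). Compound 2 `O=C1C(=O)N(Cc2ccc(-c3ccccc3)cc2)c2ccc(OC(F)(F)F)cc21` gives 1600 nM, and compound 3 `O=C1C(=O)N(Cc2ccc(-c3ccncc3)nc2)c2ccc(OC(F)(F)F)cc21` gives 4400 nM. Of the two numbers, compound 2 holds the lower one, and its gap to compound 3 lies beyond the scatter of repeated measurement.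

The step under consideration leads from compound 2 to compound 4 `O=C1C(=O)N(Cc2ccc(Oc3ccccn3)cc2)c2ccc(OC(F)(F)F)cc21`, which has not yet been measured in this assay. The change is (pyridin-2-yl)oxy in place of phenyl on an aromatic carbon. Within the data shown here, no measured pair shows this change directly, so its size can only be judged from the compounds above. Since compound 3, which also carries a pyridine ring, gives 4400 nM in this assay, a step toward a higher number is expected for compound 4, estimated as a 3.1-fold higher number from compound 2 to compound 4 (0.49 log units; beyond the scatter). Compound 4 is therefore expected to give 5000 nM, within a range from 1500 nM to 20000 nM.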

Compound 4, half-maximal effective concentration: 3200 nM
For compound 4 the middle estimate is 1.6-fold (0.19 log units) above the measured one; the measured number falls inside the stated range.
By their numbers in this assay, from the lowest: compounds 2, 4 and 3 (each within the scatter of the next, the first and the last beyond it). At a limit, above all of these: compound 1.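

In this assay the shared core now has its first comparison that differs in one place only, and it reads as a 2.0-fold higher number from compound 2 to compound 4 (0.30 log units; within the scatter). On an aromatic carbon para to a large group, (pyridin-2-yl)oxy can therefore stand in place of phenyl with no change that this measurement can distinguish, even though the entering group brings a ring nitrogen, an oxygen and hydrogen-bond acceptors that phenyl does not have. Nothing measured here accounts for this outcome.

The compounds shown do not separate the contribution of the linking oxygen from that of the ring nitrogen, and a phenoxy group at this place would be the telling comparison. They also leave open how an amine in place of that oxygen, or a carboxylic acid on the pyridine ring, would read.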